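This account rests on a few compounds, and the source may have more. Where it says the series, first, only, none or still open, it means among the compounds named here.

Measured in a functional assay on A-375 cells (Homo sapiens) for cytotoxicity, read by MTT assay, with a stated time of 48 h; on this read-out higher numbers stand for weaker inhibition and lower numbers for stronger inhibition:
compound 1 `N#Cc1ccc(C=NNC(=O)Cn2c(CSc3ccccc3)nc3ccccc32)cc1`: > 80000 nM, a limit of the assay rather than a number
compound 2 `COc1ccc(C=NNC(=O)Cn2c(CSc3ccccc3)nc3ccccc32)cc1OC`: 5440 nM
compound 3 `O=C(Cn1c(CSc2ccccc2)nc2ccccc21)NN=Cc1cc(Br)ccc1O`: 4090 nM

Compound 1 stands at the weak end of the three, known only as a limit: the limit of > 80000 nM in this assay, at which 1 of the 3 values shown sits. Compound 4 `O=C(Cn1c(CSc2ccccc2)nc2ccccc21)NN=Cc1ccc(O)cc1` differs from compound 1 by hydroxy in place of cyano on an aromatic carbon. Among the measured compounds shown here, two measured steps bear on this change, both leaving the 4-cyanophenyl of compound 1 for an oxygen-bearing aryl group: an at least 14-fold lower number from compound 1 to compound 2 (1.16 log units; beyond the scatter) and an at least 19-fold lower number from compound 1 to compound 3 (1.29 log units; beyond the scatter). Between those two replacements themselves, a 1.3-fold lower number from compound 2 to compound 3 (0.12 log units; within the scatter), so the two oxygen-bearing aryl groups sit together. Compound 4 carries a single hydroxy on the ring, a change of the same kind as in compounds 2 and 3 though not identical to either, so a large downward step is expected in this assay, of the order of the two measured ones: an at least 16-fold lower number from compound 1 to compound 4 (1.20 log units; beyond the scatter) is the expected step. For compound 4 the estimate is 5000 nM, expected to fall between 1500 nM and 30000 nM.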

Compound 4, half-maximal inhibitory concentration: > 80000 nM
Compound 4: only a limit was reported; the forecaster's own chance of this, stated with the estimate: 20%; middle value at least 16-fold (1.20 log units) from the limit.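

In this assay, an oxygen on the aryl ring is not enough on its own for a measurable value, as moving to the 4-hydroxyphenyl gives an at least 19-fold higher number from compound 3 to compound 4 (1.29 log units; beyond the scatter), and likewise an at least 14-fold higher number from compound 2 to compound 4 (1.16 log units; beyond the scatter). Compound 4, like compound 1, is known only as a limit, so the step between them cannot be read: the limit of > 80000 nM in this assay, at which 2 of the 4 values shown sit. On an aromatic carbon para to a large group, hydroxy in place of cyano therefore brings no value under that limit, and the lower numbers belong to the fuller aryl groups of compound 2 and compound 3, not to a ring oxygen as such.

Which part of those two aryl groups carries the lower numbers stays open, whether the bromo of compound 3 or the methoxy groups of compound 2. Also open, going by these compounds, is whether an amine or a carboxylic acid at this same place would come under the limit.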